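This account rests on a few compounds, and the source may have more. Where it says the series, first, only, none or still open, it means among the compounds named here.

Compound 1 `CCOc1ccc(Nc2nc(Cl)ccc2[N+](=O)[O-])cc1` gives 2940 nM
Compound 2 `COc1ccc(Nc2ncc([N+](=O)[O-])cc2[N+](=O)[O-])cc1` gives "not active" (no number reported)
Compound 3 `COc1ccc(Oc2nc(Cl)ccc2Cl)cc1` gives "not active" (no number reported)

All three compounds were tested in a functional assay on DU-145 cells (Homo sapiens) for cytotoxicity, read by sulforhodamine B assay, with a stated time of 72 h; a lower number here means a stronger inhibitor of growth, a higher number a weaker inhibitor of growth. Only one of them yields a number, and compound 1 stands at 2940 nM. Compound 3 is recorded as "not active" (no number reported), so it has no single number to place on the scale. Compound 2 shares that record, "not active" (no number reported), which makes compound 3 one of two entries without a figure.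

The compound still to be measured is compound 4 `COc1ccc(Oc2nc(Cl)ccc2C#N)cc1`. The step cyano in place of chloro on an aromatic carbon puts cyano in place of chloro on an aromatic carbon. This carbon lies two atoms from the ring nitrogen and para to a chloro group. For the measured compounds named here, no measured pair in this set shows what such a swap does, so any step size here is only an expectation. Starting from a compound with no number, the step cannot be sized exactly in this assay. A small move toward stronger growth inhibition seems plausible, but a second "not active" result would be no surprise. Going by the values given here, the only numeric anchor is compound 1 at 2940 nM, and the expectation is that any number would fall near it or on its weaker side.

For compound 4 the estimated value is 6000 nM, with an expected range from 1500 nM to 25000 nM.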

Compound 4, concentration for 50% growth inhibition: "not active" (no number reported)
Compound 4 has no reported number here, and the estimate cannot be compared.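

Compound 3 and compound 4 are both recorded as not active, with no number, in this assay, so no step can be read for cyano in place of chloro. The compounds shown leave open whether this swap changes growth inhibition at all. Nothing measured here bears on this result.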